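The source may report more compounds than this note shows. Statements on the series, on what has been measured and on what is new or still open speak of the compounds shown alone.

Series notes, cytotoxicity. Compound 1 `COc1ccc(Cn2c(SC(C)C(=O)Nc3ccc(C)cc3Cl)nc3ccccc32)cc1` is measured in an ADME assay on Vero cells (Chlorocebus sabaeus) for cytotoxicity, read by MTT assay, with a stated time of 24 h; a higher number here means that more compound is tolerated, a lower number that less compound is tolerated; compound 1 reaches only a limit of the measurement there, > 75000 nM. Compound 3 `COc1ccc(-n2c([S+]([O-])C(C)C(=O)Nc3ccc(C)cc3Cl)nc3ccccc32)cc1` also stops at a limit in this assay, with compound 3 reported as > 75000 nM. Compound 2 `COc1ccc(-n2c(SC(C)C(=O)Nc3nc(C)cc(Cl)n3)nc3ccccc32)cc1` carries no number in this assay, the entry for compound 2 standing as "not determined" (no result reported). Where compound 2 stands therefore rests on no result of its own; the two measured neighbours both sit at the limit of > 75000 nM in this assay, at which 2 of the 3 values shown sit, so the series so far shows tolerance up to the top of the tested range and nothing finer.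

The step to compound 4 `COc1ccc(-n2c(SC(C)C(=O)Nc3cc(C)no3)nc3ccccc32)cc1` changes only the group on the amide-type nitrogen: 3-methyl-1,2-oxazol-5-yl in place of 4-chloro-6-methylpyrimidin-2-yl on an amide-type nitrogen. Among the measured compounds shown here, no measured pair in the set carries this change, so the step from compound 2 to compound 4 in this assay cannot be sized from measured numbers. The working expectation is a step of no size beyond the scatter, in no particular direction, given that two of the three entries in this assay sit at the limit of > 75000 nM in this assay, at which 2 of the 3 values shown sit. Compound 4 is thus expected to come out near 75000 nM in this assay, within a range of 30000 nM to 150000 nM, most probably reported again only as a limit.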

Compound 4, half-maximal cytotoxic concentration: > 75000 nM
Compound 4 was reported as a limit; the forecaster's own chance of this, stated with the estimate: 70%; the middle value lies on the limit itself.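

In this assay compound 4 gives > 75000 nM, a limit of the assay. No new step can be read between compound 2, which carries no number, and compound 4. The compounds shown leave open the concentration at which any of them would become cytotoxic.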